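Isopropyl Added to the Side Chain of Compound 1

This account rests on a few compounds, and the source may have more. Where it says the series, first, only, none or still open, it means among the compounds named here.

Measured so far in an assay on isolated protein for inhibition of Bile acid receptor (Homo sapiens), read by TR-FRET and LanthaScreen; a higher number here means a weaker inhibitor, a lower number a stronger inhibitor:
compound 1 `C[C@@H](c1nc2ccc(C(=O)O)cc2n1C)N1C(=O)CN(c2ccc(Oc3ccccc3)cc2)C1=O` gives 10400 nM
compound 2 `CC(C)C[C@@H](c1nc2ccc(C(=O)O)cc2n1C)N1C(=O)N(c2ccc(Oc3ccccc3)cc2)C(C)(C)C1=O` gives 105000 nM
compound 3 `CC(C)C[C@@H](c1nc2ccc(C(=O)O)cc2n1C)N1CCN(c2ccc(Oc3ccccc3)cc2)C1=O` gives 28500 nM

Compound 1 stands lowest of the three numbers in this assay. Its nearest neighbour is compound 3, whose number lies higher by a step beyond the usual scatter; compound 2 lies furthest, higher still. Compound 4 `CC(C)C[C@@H](c1nc2ccc(C(=O)O)cc2n1C)N1C(=O)CN(c2ccc(Oc3ccccc3)cc2)C1=O` differs from compound 1 by isopropyl in place of hydrogen on a saturated chain carbon, two bonds along the chain from an amide-type nitrogen in a ring and an aromatic carbon, that is, the same change read one bond further out is methyl to isobutyl. Within the data shown here, no measured pair shows this change on the core of compound 1; compounds 2 and 3 carry that isobutyl chain, yet on cores of their own, so their higher numbers offer only a loose hint. A modest rise is expected, a 1.9-fold higher number from compound 1 to compound 4 (0.28 log units; within the scatter). Compound 4 is estimated at 20000 nM, with a range from 6000 nM to 65000 nM.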

Compound 4, half-maximal inhibitory concentration: 43400 nM
The estimate for compound 4 lay 2.2-fold (0.34 log units) below the measured number, and the stated range covers the measured number.
By their numbers in this assay, from the lowest: compound 1; then compounds 3 and 4 (each within the scatter of the next); then compound 2.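

On the shared core, in this assay, isopropyl in place of hydrogen on this saturated chain carbon gives a 4.2-fold higher number from compound 1 to compound 4 (0.62 log units; beyond the scatter), a modest step beyond the scatter. This is a direct reading of the change with nothing else altered, which compounds 2 and 3, on cores of their own, could not give. Nothing at hand explains the rise. Open, from the compounds shown here alone, is how the number moves with a shorter chain such as ethyl, a longer chain, or a chain ending in an amine at this carbon. Also open, going by these compounds, is whether the same step holds on other cores.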